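The source may report more compounds than this note shows. Statements on the series, on what has been measured and on what is new or still open speak of the compounds shown alone.

Of the compounds shown here, three sharing one core have been measured in an ADME assay on Vero cells (Chlorocebus sabaeus) for cytotoxicity, read by fluorescence and resazurin assay, with a stated time of 3 days; on this read-out higher numbers stand for lower toxicity in this test and lower numbers for higher toxicity in this test. Compound 1 `CC(=O)C[C@H]1O[C@@H](On2cc(CN3C(=O)/C(=N\Nc4ccc(Br)cc4)c4ccccc43)nn2)[C@H](OC(C)=O)[C@@H](OC(C)=O)[C@@H]1OC(C)=O` gives 116000 nM. Compound 2 `CC(=O)C[C@H]1O[C@@H](On2cc(CN3C(=O)/C(=N\Nc4ccc(C#N)cc4)c4ccccc43)nn2)[C@H](OC(C)=O)[C@@H](OC(C)=O)[C@@H]1OC(C)=O`, which carries cyano in place of bromo on an aromatic carbon, gives 75400 nM, and the step of a 1.5-fold lower number from compound 1 to compound 2 (0.19 log units; within the scatter). Compound 3 `CC(=O)C[C@H]1O[C@@H](On2cc(CN3C(=O)/C(=N\Nc4ccc(Br)cc4)c4ccccc43)nn2)[C@H](OC(C)=O)[C@@H](OC(C)=O)[C@H]1OC(C)=O` gives 83400 nM, which places it second highest of the three numbers, with compound 2 nearest and compound 1 furthest, both within the scatter. Compound 3 and compound 1 are related only through (the fact that compounds 1 and 3 differ only in the configuration as drawn), and the step of a 1.4-fold lower number from compound 1 to compound 3 (0.14 log units; within the scatter).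

Compound 4 `CC(=O)C[C@H]1O[C@@H](On2cc(CN3C(=O)/C(=N\Nc4ccc(C#N)cc4)c4ccccc43)nn2)[C@H](OC(C)=O)[C@@H](OC(C)=O)[C@H]1OC(C)=O` has not yet been measured in this assay. Its difference from compound 3 is cyano in place of bromo on an aromatic carbon. Among the measured compounds shown here, the one measured step that bears on this change is the same exchange made on the other diastereomer, a 1.5-fold lower number from compound 1 to compound 2 (0.19 log units; within the scatter), which stayed within the scatter. It is therefore expected that the step from compound 3 to compound 4 in this assay will also stay within the scatter, perhaps with a small downward lean, a 1.3-fold lower number from compound 3 to compound 4 (0.13 log units; within the scatter). Compound 4 is estimated to give 62000 nM in this assay, with a plausible range from 30000 nM to 125000 nM.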

Compound 4, half-maximal cytotoxic concentration: 75500 nM
For compound 4 the middle estimate is 1.2-fold (0.09 log units) below the measured one, and the stated range covers the measured number.
By their numbers in this assay, from the lowest: compounds 2, 4, 3 and 1 (each within the scatter of the next).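

With the exchange of bromo for cyano on an aromatic carbon, para to a large group, now read on both diastereomers in this assay the second case gives a 1.1-fold lower number from compound 3 to compound 4 (0.04 log units; within the scatter) and the two steps agree: the same change on two cores in this assay, a 1.5-fold lower number (0.19 log units; within the scatter) from compound 1 to compound 2 and a 1.1-fold lower number (0.04 log units; within the scatter) from compound 3 to compound 4, 1.4-fold (0.14 log units) apart, within the scatter of two such steps. The drawn configuration at the saturated ring carbon had until now been read only with bromo in place, and with cyano it gives a 1.0-fold higher number from compound 2 to compound 4 (0.00 log units; within the scatter) so that this change too stays within the scatter with either group: the fact that compounds 2 and 4 differ only in the configuration as drawn. The four compounds thus close a square in which neither change, on either partner, moves the number beyond the scatter, and no interplay between the aromatic group and the configuration can be seen in this read-out.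

Bromo and cyano are the only two groups shown at this position, so it remains open whether an amine, a carboxylic acid or a methoxy group there would give a step beyond the scatter. Going by these compounds, it also remains open whether free hydroxyl groups in place of the acetate esters on the saturated ring would leave the numbers where they stand.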